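The source may hold more compounds than are shown below. What is called first, only, known or untested is meant among the compounds shown, and "the series" means these compounds.

Measured so far in a functional assay on TK-10 cells (Homo sapiens) for inhibition, read by sulforhodamine B assay, with a stated time of 48 h; on this read-out lower numbers stand for stronger inhibition of growth and higher numbers for weaker inhibition of growth:

compound 1, `Nc1cc(N)c2nc(-c3ccccc3)c(Sc3ccc(F)cc3)nc2c1`: < 100000 nM, a limit of the assay and not a number
compound 2, `COc1cc(CNc2nc3cc(N)cc(N)c3nc2-c2ccccc2)cc(OC)c1OC`: 17800 nM
compound 3, `CCOC(=O)[C@H](CCC(=O)O)NC(=O)c1ccc(CNc2nc3cc(N)cc(N)c3nc2-c2ccccc2)cc1`: < 100000 nM, again a limit and not a number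

Compound 1 therefore stands at the limit of < 100000 nM in this assay, at which 2 of the 3 values shown sit; only compound 2 gives a number in this assay, and compound 3 shares the limit of compound 1. The unmeasured compound 4, `Nc1cc(N)c2nc(-c3ccccc3)c(NCc3ccc(F)cc3)nc2c1`, differs from compound 1 by (4-fluorobenzyl)amino in place of (4-fluorophenyl)sulfanyl on an aromatic carbon. Going by the values given here, no step between two measured compounds is available to calibrate this change; what the series shows is that compound 2, with a benzylamino substituent at the same place, gives 17800 nM. Compound 3, with a larger benzylamino substituent, remains at the limit of the assay. Compound 4 is therefore expected to move out of the limit into the measurable range, but not far, with an estimate of 35000 nM and a range of 9000 nM to 100000 nM. That estimate corresponds to an expected step that the limit leaves unreadable from compound 1 to compound 4, with a real chance that this assay again returns only a limit for compound 4.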

Compound 4, concentration for total growth inhibition: 20000 nM
Estimate against measurement, compound 4: 1.8-fold (0.24 log units) above, within the range that was stated.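

Compound 1 carries a limit and not a number, so no step between compound 1 and compound 4 can be read: the limit of < 100000 nM in this assay, at which 2 of the 4 values shown sit.

The compounds shown leave open how large the change from (4-fluorophenyl)sulfanyl to (4-fluorobenzyl)amino is, and in which direction it runs.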